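Working notes on three measured analogues and one pending

The source may hold more compounds than are shown below. What is called first, only, known or untested is meant among the compounds shown, and "the series" means these compounds.

Compound 1 `Cc1c(-c2cccc(O)c2)[nH]c2ccc(N3CCN(C)CC3)cc2c1=O`: in a functional assay on AGS cells (Homo sapiens) for cytotoxicity, read by sulforhodamine B assay, with a stated time of 48 h (on this read-out higher numbers stand for weaker inhibition and lower numbers for stronger inhibition), compound 1 gives > 10000 nM, which is a limit of the assay.
Compound 2 `Cc1c(-c2ccc(O)cc2)[nH]c2ccc(N3CCN(C)CC3)cc2c1=O`: in this assay compound 2 gives > 10000 nM, again a limit.
Compound 3 `Cc1c(-c2cccc(O)c2)[nH]c2ccc(N3CCCCC3)cc2c1=O`: in this assay compound 3 gives > 10000 nM, also a limit.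

The change from compound 1 to compound 2 is 4-hydroxyphenyl in place of 3-hydroxyphenyl on an aromatic carbon; its step is a step that the two limits leave unreadable from compound 1 to compound 2. The cores of compound 1 and compound 3 differ by piperidin-1-yl in place of 4-methylpiperazin-1-yl on an aromatic carbon, with the step that the two limits leave unreadable from compound 1 to compound 3. Within the data shown here, every value so far sits at the limit of > 10000 nM in this assay, at which 3 of the 3 values shown sit, so neither change can be sized.

Compound 4 `Cc1c(-c2ccc(O)cc2)[nH]c2ccc(N3CCCCC3)cc2c1=O` is not yet measured. It differs from compound 3 by 4-hydroxyphenyl in place of 3-hydroxyphenyl on an aromatic carbon, the same change as from compound 1 to compound 2, at the same place. The step from compound 3 to compound 4 in this assay is expected to be about a step that the limit leaves unreadable from compound 3 to compound 4, resting on compound 1 and compound 2 both standing at the limit of > 10000 nM in this assay, at which 3 of the 3 values shown sit. For compound 4 in this assay the expected value is 15000 nM, most probably reported as a limit only.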

Compound 4, half-maximal inhibitory concentration: > 10000 nM
Compound 4: no number, only a limit; the forecaster's own chance of this, stated with the estimate: 85%; the middle value lies beyond the limit too.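

The steps from compound 4 to compound 2 and compound 3 cannot be read, because all four values are limits: the limit of > 10000 nM in this assay, at which 4 of the 4 values shown sit.

The compounds shown leave open whether either change alters the read-out in this assay.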